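Fluoro on the benzyloxy amide: tolerance across two cores

The source may report more compounds than this note shows. Statements on the series, on what has been measured and on what is new or still open speak of the compounds shown alone.

Compound 1 `O=C(NOCc1ccccc1)c1cn(-c2ccccc2)nc1-c1ccccc1` is the parent of the set. In an ADME assay on HEK-293T cells (Homo sapiens) for antiproliferative activity, read by MTT assay, with a stated time of 48 h, in the presence of a further agent that is not named here (a higher number here means that more compound is tolerated, a lower number that less compound is tolerated), compound 1 gives 122000 nM. Compound 2 `O=C(NOCc1ccccc1F)c1cn(-c2ccccc2)nc1-c1ccccc1` differs from it by fluoro in place of hydrogen on an aromatic carbon, and in this assay compound 2 gives 75700 nM; the step is a 1.6-fold lower number from compound 1 to compound 2 (0.21 log units; within the scatter). Compound 3 `COc1ccc(-c2nn(-c3ccccc3)cc2C(=O)NOCc2ccccc2)cc1` differs from compound 1 by methoxy in place of hydrogen on an aromatic carbon, and in this assay compound 3 gives 201000 nM, with a 1.6-fold higher number from compound 1 to compound 3 (0.22 log units; within the scatter). Among the compounds with values here, no step between compound 2 and compound 3 is worked out here; their two values simply stand as given, and of the three numbers compound 3 has the highest.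

Compound 4 `COc1ccc(-c2nn(-c3ccccc3)cc2C(=O)NOCc2ccccc2F)cc1` has not been measured in this assay. It differs from compound 3 by fluoro in place of hydrogen on an aromatic carbon. This is the same change that takes compound 1 to compound 2, and the surroundings of the place are described in identical words for both pairs, so the two changes are the same; the cores differ by methoxy in place of hydrogen on an aromatic carbon.

Within the data shown here, the expectation for compound 4 rests on the single measured example: because the step of a 1.6-fold lower number from compound 1 to compound 2 (0.21 log units; within the scatter) stayed within the scatter, the step from compound 3 to compound 4 is expected to be of a like size, a 1.6-fold lower number from compound 3 to compound 4 (0.21 log units; within the scatter). Compound 4 is accordingly estimated at 125000 nM in this assay, with a range from 60000 nM to 260000 nM reflecting that one prior example is a thin basis.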

Compound 4, half-maximal cytotoxic concentration: 24600 nM
For compound 4 the middle estimate is 5.1-fold (0.71 log units) above the measured one, and the stated range ends above it.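

In this assay fluoro in place of hydrogen on an aromatic carbon does not carry over unchanged from the core of compound 1 to the core of compound 3: the new step is an 8.2-fold lower number from compound 3 to compound 4 (0.91 log units; beyond the scatter) and it stands apart from the earlier one: the same change on two cores in this assay, a 1.6-fold lower number (0.21 log units; within the scatter) from compound 1 to compound 2 and an 8.2-fold lower number (0.91 log units; beyond the scatter) from compound 3 to compound 4, 5.1-fold (0.70 log units) apart, beyond the scatter of two such steps

Seen from the other side of the same four compounds, methoxy in place of hydrogen on an aromatic carbon gives a 3.1-fold lower number from compound 2 to compound 4 (0.49 log units; beyond the scatter) and likewise fails to match its counterpart on the core without fluoro: the same change on two cores in this assay, a 1.6-fold higher number (0.22 log units; within the scatter) from compound 1 to compound 3 and a 3.1-fold lower number (0.49 log units; beyond the scatter) from compound 2 to compound 4, 5.1-fold (0.70 log units) apart, beyond the scatter of two such steps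

So, in this series, the size of a step on one core did not transfer to the other core, and the two changes together do not equal the sum of their single steps; this rests on a single set of four compounds, and it shows neither why the steps differ nor whether the same holds for any other pair of groups or in any other assay.

Open, from the compounds shown here alone, is whether chloro or methyl in place of the fluoro on the 2-fluorobenzyl group would show the same dependence on the core. Also open, going by these compounds, is whether a hydroxyl or an amine in place of the methoxy would leave the fluoro step as small as on the core of compound 1.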